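The compounds below may be only part of what the source reports. "The series", "measured", "known", "first", "only" and "open" are said of these compounds alone.

Compound 1 `OC[C@H]1O[C@@H](n2cc(F)c3c(-c4ccsc4)ncnc32)[C@H](O)[C@@H]1O`: 380 nM
Compound 2 `OC[C@H]1O[C@@H](n2cc(Cl)c3c(-c4cccs4)ncnc32)[C@H](O)[C@@H]1O`: 380 nM

In a functional assay on A549 cells (Homo sapiens), read by sulforhodamine B assay, with a stated time of 5 days (on this read-out higher numbers stand for weaker inhibition of growth and lower numbers for stronger inhibition of growth), compound 2 gives 380 nM, the same figure as compound 1 at 380 nM. Compound 3 `OC[C@H]1O[C@@H](n2cc(Cl)c3c(-c4ccsc4)ncnc32)[C@H](O)[C@@H]1O` has thiophen-3-yl in place of thiophen-2-yl on an aromatic carbon of compound 2 (thiophen-3-yl in place of thiophen-2-yl on an aromatic carbon). Going by the values given here, no measured pair shows this change alone, so the data give no direct guide to its size. A step within the scatter is expected in this assay, in neither direction. The estimated value for compound 3 is 330 nM, with an expected range of 120 nM to 900 nM. This estimate means an expected 1.2-fold lower number from compound 2 to compound 3 (0.06 log units; within the scatter).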

Compound 3, concentration for 50% growth inhibition: 380 nM
Compound 3: middle estimate off by 1.2-fold (0.06 log units), on the low side, and the stated range covers the measured number.
By their numbers in this assay, from the lowest: compounds 1, 2 and 3 (each within the scatter of the next).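

In this assay, thiophen-3-yl in place of thiophen-2-yl gives no change at the digits printed from compound 2 to compound 3 (within the scatter) and thus shows that, with chloro held, this position reads the same with either thiophene attachment. Chloro in place of fluoro, with thiophen-3-yl held, gives no change at the digits printed from compound 1 to compound 3 (within the scatter) as the first direct reading of that halogen swap. No available evidence bears on why these pairs read alike. Still open, from the compounds shown here alone, is how an amine or a furan-2-yl would read on the carbon that carries the thiophene. Also open, going by these compounds, is whether methyl in place of the halogen would read the same.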